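A few compounds are considered here, and "the series" means these few. Any claim that something is new, unique, unknown or untested is made for them only; others in the source may bear on it.

Compounds measured in an assay on COS-7 cells for inhibition of patatin-like phospholipase domain-containing protein 2 (Mus musculus), tested at 200 uM; a lower number here means less inhibition, a higher number more inhibition at the concentration tested (going by the name of the read-out):
compound 1 `CCNS(=O)(=O)c1cccc(-c2ccc(OCC)cc2)c1` gives 46%
compound 2 `CCOc1ccc(-c2cccc(C(=O)O)c2)cc1` gives 23%
compound 3 `CCOc1ccc(-c2cccc(C(=O)N3CCCC3)c2)cc1` gives 53%

Compound 3 stands highest of the three numbers in this assay. Its nearest is compound 1, with the step of a number 7 percentage points higher from compound 1 to compound 3 (within the scatter), and its furthest is compound 2, with the step of a number 30 percentage points higher from compound 2 to compound 3 (beyond the scatter). Among the compounds with values here, only the step from compound 2 is beyond the scatter, so compound 3 and compound 1 cannot be ordered against each other.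

Compound 4 `CCOc1ccc(-c2cccc(C(=O)NC)c2)cc1` is not yet measured in this assay. It differs from compound 3 as follows: methylamino in place of pyrrolidin-1-yl on a carbonyl carbon

Within the data shown here, two measured steps bear on this change on the carbonyl carbon. The step of a number 30 percentage points higher from compound 2 to compound 3 (beyond the scatter) shows that pyrrolidin-1-yl in place of hydroxy raises the read-out beyond the scatter, and the step of a number 23 percentage points lower from compound 1 to compound 2 (beyond the scatter) shows the carboxy compound as the lowest of the set. Among the measured compounds shown here, no measured pair carries methylamino, so the size of the step for this amine is open. Methylcarbamoyl lies between carboxy and (pyrrolidin-1-yl)carbonyl in this series, and a step downward from compound 3, smaller than the step from compound 2, is expected. The expected step is a number 15 percentage points lower from compound 3 to compound 4 (beyond the scatter). Compound 4 is estimated at 38%, with a range from 20% to 55%.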

Compound 4, a percentage reported as inhibition, at one concentration (the size of the read-out at that concentration, not a potency): 40%
Beside the measured number, compound 4's estimate is 2 percentage points below it; low and high end bracket the measured number.
By their numbers in this assay, from the lowest: compound 2; then compounds 4, 1 and 3 (each within the scatter of the next, the first and the last beyond it).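

In this assay, the read-out at the carbonyl carbon depends on which amine is attached: methylamino in place of pyrrolidin-1-yl gives a number 13 percentage points lower from compound 3 to compound 4 (beyond the scatter), and methylamino in place of hydroxy gives a number 17 percentage points higher from compound 2 to compound 4 (beyond the scatter), so the two amides are separated from each other as well as from the carboxy compound. On the aromatic carbon, methylcarbamoyl in place of ethylsulfamoyl gives a number 6 percentage points lower from compound 1 to compound 4 (within the scatter), so these two groups cannot be ordered here, although the (pyrrolidin-1-yl)carbonyl to methylcarbamoyl change can be. Nothing available here accounts for the gap between the two amides.

Still open, on these data alone, is whether that gap follows the amide hydrogen or the ring: dimethylamino on the same carbonyl carbon has the hydrogen gone without a ring, whereas piperidin-1-yl or a longer chain such as ethylamino would test the size and shape of the amine. As far as these compounds go, it is also open whether a plain amino group on that carbonyl carbon stays clear of the carboxy compound, and readings at one concentration give no potency for any of these amides.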